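Compound 2 to compound 4: pyridin-3-yl becomes pyridin-4-yl

A few compounds are considered here, and "the series" means these few. Any claim that something is new, unique, unknown or untested is made for them only; others in the source may bear on it.

Measured so far in a physicochemical assay for lipophilicity, read by HPLC, measured as chromatographic lipophilicity, at pH 7.4; a lower number here means a more polar compound, a higher number a more lipophilic compound
compound 1 `O=C(C1CCN(c2ccccc2)CC1)N1N=CC[C@H]1c1ccccc1` gives 6.3
compound 2 `O=C(c1cccnc1)N1N=CCC1c1ccccc1` gives 2.7
compound 3 `Cc1nnc(N2CCC(C(=O)N3N=CC[C@H]3c3cc(F)cc(F)c3)CC2)o1` gives 3.6

Compound 2 has the lowest of the three numbers at 2.7 in this assay and so is the most polar of them on this read-out. Compound 3 is the nearest at 3.6 and compound 1 the furthest at 6.3 with both gaps beyond the scatter. For the measured compounds named here, these three compounds differ in more than one place, so no measured pair shows the size of a single exchange.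

The next compound to be measured is compound 4 `O=C(c1ccncc1)N1N=CCC1c1ccccc1` and it has the same atoms as compound 2, joined differently. The change is pyridin-4-yl in place of pyridin-3-yl on a carbonyl carbon and in words it puts pyridin-4-yl in place of pyridin-3-yl on a carbonyl carbon. The counted features stay the same on both sides of the exchange. Going by the values given here, the expectation therefore rests on this structural change and on compound 2 at 2.7 with no measured precedent for the exchange. The step expected in this assay is no change at the digits printed from compound 2 to compound 4 (within the scatter) with no shift beyond the scatter in either direction. The estimated value for compound 4 is 2.7 (2.3 to 3.1).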

Compound 4, distribution coefficient: 2.7
Beside the measured number, compound 4's estimate shows no gap at the digits printed; the range from low to high includes it.
By their numbers in this assay, from the lowest: compounds 2 and 4 (each within the scatter of the next); then compound 3; then compound 1.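

For the compounds shown here, the pair gives the series its first exchange in a single place, which the earlier compounds could not provide: in this assay, pyridin-4-yl in place of pyridin-3-yl on a carbonyl carbon, whose other neighbour is an amide-type nitrogen in a ring, gives no change at the digits printed from compound 2 to compound 4 (within the scatter). On this read-out, the two groups are therefore not separated at this position on the shared core, although this rests on one pair only and does not extend to the other compounds in the series. No available measurement bears on why the exchange leaves the reading as it stands.

Still open, on these data alone, is whether pyridin-2-yl on the same carbonyl carbon, or an amine or a carboxylic acid carried on the pyridine ring, would stay within the scatter of compound 2 at 2.7 in this assay. Also open, as far as these compounds go, is whether the exchange of pyridin-3-yl for pyridin-4-yl would read the same on a core with a further group, such as methoxy, added to it.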